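The source may hold more compounds than are shown below. What is called first, only, known or untested is meant among the compounds shown, and "the series" means these compounds.

Compound 1 `Oc1ccc(CNc2ncnc3c2ncn3C2CCCCO2)cc1`: in an ADME assay on K562 cells (Homo sapiens) for cytotoxicity, with a stated time of 72 h (on this read-out higher numbers stand for weaker inhibition and lower numbers for stronger inhibition), compound 1 gives > 100000 nM, which is a limit of the assay, not a number.
Compound 2 `COc1ccc(CNc2ncnc3c2ncn3C2CCCCO2)cc1`: in this assay compound 2 gives > 100000 nM, again a limit.
Compound 3 `COc1cc(CNc2ncnc3c2ncn3C2CCCCO2)ccc1O`: in this assay compound 3 gives > 100000 nM, also a limit.

All three share a core, and all three sit at the limit of > 100000 nM in this assay, at which 3 of the 3 values shown sit. Compound 1 and compound 2 differ by methyl in place of hydrogen on an oxygen on an aromatic ring, a step recorded as a step that the two limits leave unreadable from compound 1 to compound 2. Compound 1 and compound 3 differ by methoxy in place of hydrogen on an aromatic carbon, a step recorded as a step that the two limits leave unreadable from compound 1 to compound 3.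

Compound 4 `COc1ccc(CNc2ncnc3c2ncn3C2CCCCO2)c(OC)c1` has not been measured. It differs from compound 2 by methoxy in place of hydrogen on an aromatic carbon. For the measured compounds named here, this is the same kind of change as the one from compound 1 to compound 3, but not the same: there the entering methoxy sat ortho to a hydroxy group and meta to a large group, whereas here it sits ortho to a large group and meta to a methoxy group. Because compound 2 gives > 100000 nM and the corresponding step that the two limits leave unreadable from compound 1 to compound 3 could not be read, the step from compound 2 to compound 4 in this assay is expected to be a number no higher from compound 2 to compound 4 (the limit leaves the size open). Compound 4 is therefore estimated at 100000 nM.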

Compound 4, half-maximal inhibitory concentration: > 25000 nM
Compound 4 was reported as a limit; the forecaster's own chance of this, stated with the estimate: 85%; the middle value lies beyond the limit too.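

Compound 2 and compound 4 are both reported only as limits, so the step between them cannot be read, and adding the methoxy gives no size to report. From the compounds shown here alone, with all four compounds at limits, what stays open is whether any of them has a real inhibitory value in this assay, and whether any of these changes shifts it.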